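Swapping the sugar for a hydroxyethoxymethyl chain

The source may report more compounds than this note shows. Statements on the series, on what has been measured and on what is new or still open speak of the compounds shown alone.

Compound 2 `NC(=O)c1nc(C#Cc2ccc(C(F)(F)F)cc2)n([C@@H]2O[C@H](CO)[C@@H](O)[C@H]2O)n1` was examined in an ADME assay on HuH6 cells (Homo sapiens) for cytotoxicity; on this read-out lower numbers stand for higher toxicity in this test and higher numbers for lower toxicity in this test. In this assay compound 2 reaches only a limit, > 120000 nM. Compound 3 `COC(=O)c1nc(C#CC2(O)CCCC2)n([C@@H]2O[C@H](COC(C)=O)[C@@H](OC(C)=O)[C@H]2OC(C)=O)n1` likewise returns only a limit in this assay, > 105000 nM. Compound 1 `NC(=O)c1nc(C#Cc2ccc(F)cc2)n(COCCO)n1` gives 132000 nM in this assay, and it already carries the (2-hydroxyethoxy)methyl chain on the aromatic nitrogen. Compound 2 thus sits at the top of the numbers shown, next to the limit of > 120000 nM in this assay, at which 1 of the 3 values shown sits, and (the limit of > 105000 nM in this assay, at which 1 of the 3 values shown sits). Compound 4 `NC(=O)c1nc(C#Cc2ccc(C(F)(F)F)cc2)n(COCCO)n1` differs from compound 2 in one place: (2-hydroxyethoxy)methyl in place of 3,4-dihydroxy-5-(hydroxymethyl)oxolan-2-yl on an aromatic nitrogen. Among the measured compounds shown here, no measured pair shows this change, so the step from compound 2 to compound 4 is expected to be a number no higher from compound 2 to compound 4 (the limit leaves the size open), nothing beyond the scatter. Compound 4 is estimated to give 120000 nM in this assay, with a range from 60000 nM to 250000 nM.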

Compound 4, half-maximal cytotoxic concentration: 87500 nM
Estimate against measurement, compound 4: 1.4-fold (0.14 log units) above, and the stated range covers the measured number.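

Compound 2 gives only a limit in this assay, > 120000 nM. The exchange of its sugar for the (2-hydroxyethoxy)methyl chain on an aromatic nitrogen can therefore be read only as a floor: an at least 1.3-fold lower number from compound 2 to compound 4 (0.13 log units; that floor lies within the scatter). With that chain kept in place, trifluoromethyl in place of fluoro on an aromatic carbon gives a 1.5-fold lower number from compound 1 to compound 4 (0.18 log units; within the scatter). Nothing measured here gives a cause for either step. From the compounds shown here alone, whether a longer chain on the aromatic nitrogen, or a carboxylic acid in place of the carbamoyl group, would carry the number beyond the scatter stays open.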